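Removing one methoxy group from compound 2

A few compounds are considered here, and "the series" means these few. Any claim that something is new, unique, unknown or untested is made for them only; others in the source may bear on it.

Measured so far:
- compound 1 `COc1ccc(-c2cc(/C=C/C(=O)c3ccc(N)cc3)[nH]n2)cc1`: 5570 nM
- compound 2 `COc1cc(-c2cc(/C=C/C(=O)c3ccc(N)cc3)[nH]n2)cc(OC)c1OC`: 3510 nM

Both compounds were tested in a functional assay on NCI-H226 cells (Homo sapiens) for inhibition, read by sulforhodamine B assay, with a stated time of 48 h; on this read-out lower numbers stand for stronger inhibition of growth and higher numbers for weaker inhibition of growth. Compound 2 has the lowest of the two numbers at 3510 nM, but its nearest neighbour, compound 1, lies only a short distance away at 5570 nM, and that gap is within the scatter of repeated runs. The two values therefore show no difference that can be relied on.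

Compound 3 `COc1ccc(-c2cc(/C=C/C(=O)c3ccc(N)cc3)[nH]n2)cc1OC` has not yet been measured in this assay . It differs from compound 2 in one place: hydrogen in place of methoxy on an aromatic carbon, on an aromatic carbon of a six-membered aromatic ring of carbon only, ortho to a methoxy group and meta to a large group and to another methoxy group. Going by the values given here, no step between measured compounds is available for this particular change, so the expectation rests on the two values alone. Since compound 1 and compound 2 sit within the scatter of each other, the step from compound 2 to compound 3 is expected to be small or none beyond the scatter, a 1.3-fold higher number from compound 2 to compound 3 (0.11 log units; within the scatter). Compound 3 is estimated at 4500 nM, with a range from 2000 nM to 10000 nM.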

Compound 3, concentration for total growth inhibition: 7380 nM
Compound 3: the middle estimate sits 1.6-fold (0.21 log units) below what was measured; the range from low to high includes it.
By their numbers in this assay, from the lowest: compounds 2, 1 and 3 (each within the scatter of the next, the first and the last beyond it).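

In this assay this position now has its first step beyond the scatter: hydrogen in place of methoxy on this aromatic carbon, ortho to a methoxy group, gives a 2.1-fold higher number from compound 2 to compound 3 (0.32 log units; beyond the scatter), a modest loss of inhibition of growth. The other single change, methoxy in place of hydrogen on an aromatic carbon, gives a 1.3-fold higher number from compound 1 to compound 3 (0.12 log units; within the scatter) and so separates nothing, which means a methoxy change can be readable on one ring pattern and not on another. Nothing at hand accounts for either step.

Going by these compounds, whether the modest step belongs to methoxy itself or would hold for other small groups on this carbon remains open, and a hydroxy group, a fluorine atom or an ethoxy group there would bear on that question. On these data alone, each step also rests on a single pair of compounds in one cell line, so it remains open whether the same change would give a similar step on a core carrying something other than the amine, such as an amide or a carboxylic acid.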